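This account rests on a few compounds, and the source may have more. Where it says the series, first, only, none or still open, it means among the compounds named here.

Measured so far:
compound 1 `O=C1C=C(N2CCC2)C(=O)c2c1nc1n2[C@H]2OC[C@@H](O)[C@H]2OC1`: > 16000 nM
compound 2 `COc1ccccc1NC1=CC(=O)c2c(nc3n2[C@H]2OC[C@@H](O)[C@H]2OC3)C1=O`: 6580 nM

Compound 1 carries an azetidin-1-yl group on the shared core. In a functional assay on MCF7 cells (Homo sapiens) for inhibition, read by sulforhodamine B assay (on this read-out lower numbers stand for stronger inhibition and higher numbers for weaker inhibition), compound 1 gives > 16000 nM; this is a limit of the assay, not a number, and compound 1 sits at the limit of > 16000 nM in this assay, at which 1 of the 2 values shown sits. For the measured compounds named here, compound 2 is the only member of the pair with a measured number: in this assay compound 2 gives 6580 nM. Going by the values given here, no step between compound 1 and compound 2 is established, so the two values show only that one reaches a number and the other does not.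

Compound 3 `COc1cccc(NC2=CC(=O)c3nc4n(c3C2=O)[C@H]2OC[C@@H](O)[C@H]2OC4)c1` has not yet been measured. It differs from compound 1 in one place: (3-methoxyphenyl)amino in place of azetidin-1-yl on a double-bonded ring carbon. A step in this assay toward stronger inhibition is expected, beyond the scatter, and its size is estimated as an at least 2.9-fold lower number from compound 1 to compound 3 (0.46 log units; beyond the scatter), with compound 2 at 6580 nM as the nearest reference point for an arylamino substituent on this core. Compound 3 is expected to give about 5500 nM, with a likely range from 1800 nM to 16000 nM; a result reported only as a limit remains possible.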

Compound 3, half-maximal inhibitory concentration: > 4000 nM
Compound 3: no number, only a limit; the forecaster's own chance of this, stated with the estimate: 25%; the middle value lies beyond the limit too.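

In this assay compound 3 gives > 4000 nM, which is a limit and not a number. For the compounds shown here, compound 1 gives > 16000 nM, also a limit, so no step between compound 1 and compound 3 can be read. Still open, as far as these compounds go, is how (3-methoxyphenyl)amino compares with azetidin-1-yl on the shared core in this assay.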